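This account rests on a few compounds, and the source may have more. Where it says the series, first, only, none or still open, it means among the compounds named here.

Of the compounds shown here, two have so far been measured in a functional assay on RAW264.7 cells (Mus musculus) for inhibition; a higher number here means a weaker inhibitor, a lower number a stronger inhibitor. Compound 1 `CC1=C(c2cc[n+]([O-])cc2)S(=O)(=O)N(Cc2ccc(C(=O)N3CCCCC3)cc2)C1=O` gives 79400 nM in this assay. Compound 2 `CC(C)(C)OC(=O)N(C(=O)OC(C)(C)C)C(=O)c1ccc(CN2C(=O)c3ccccc3S2(=O)=O)cc1` gives 33400 nM in this assay; its number is the lower of the two, and the gap to compound 1 lies beyond the usual scatter, so compound 2 is the stronger inhibitor of the pair. Compound 3 `CC(C)(C)OC(=O)N(Cc1ccco1)C(=O)c1ccc(CN2C(=O)c3ccccc3S2(=O)=O)cc1` has not been measured yet. It differs from compound 2 in one place: (furan-2-yl)methyl in place of tert-butoxycarbonyl on an amide-type nitrogen. Among the measured compounds shown here, no pair of measured compounds shows what such an exchange does, so no step beyond the scatter is expected in either direction. The estimated step is a 1.1-fold lower number from compound 2 to compound 3 (0.05 log units; within the scatter). Compound 3 is therefore expected to give about 30000 nM in this assay, within a range from 10000 nM to 90000 nM.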

Compound 3, half-maximal inhibitory concentration: 2610 nM
Compound 3: the middle estimate sits 11-fold (1.06 log units) above what was measured; the measured number lies below the stated range.
By their numbers in this assay, from the lowest: compound 3; then compound 2; then compound 1.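

In this assay, putting (furan-2-yl)methyl in place of one tert-butoxycarbonyl on the amide-type nitrogen gives a 13-fold lower number from compound 2 to compound 3 (1.11 log units; beyond the scatter), so the group at this position has a large effect on the number. The two groups are close in heavy-atom count, but the exchange places a five-membered aromatic ring where there was no ring, while the other tert-butoxycarbonyl remains. Nothing available explains why this exchange has so large an effect.

From the compounds shown here alone, it remains open whether the furan ring's oxygen matters, or whether any aromatic ring would do; benzyl or (thiophen-2-yl)methyl at this position would help separate these possibilities. Going by these compounds, it is also open whether the remaining tert-butoxycarbonyl contributes, which a simple methyl group in its place could test.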